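Chain extension at the aryl substituent: sulfonate versus sulfonamide series

A few compounds are considered here, and "the series" means these few. Any claim that something is new, unique, unknown or untested is made for them only; others in the source may bear on it.

Working notes on four compounds measured or to be measured in a functional assay on HT-29 cells (Homo sapiens) for cytotoxicity, read by sulforhodamine B assay, with a stated time of 48 h; a higher number here means a weaker inhibitor, a lower number a stronger inhibitor.

Compound 1 `CCNC(=O)Nc1ccc(S(=O)(=O)Oc2ccccc2CC)cc1` gives 12000 nM in this assay. Compound 2 `CCCc1ccccc1OS(=O)(=O)c1ccc(NC(=O)NCC)cc1` gives 2400 nM in this assay. The change between them is methyl in place of hydrogen on a saturated chain carbon, two bonds along the chain from an aromatic carbon, and the step it made is a 5.0-fold lower number from compound 1 to compound 2 (0.70 log units; beyond the scatter).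

Compound 3 `CCNC(=O)Nc1cccc(S(=O)(=O)Nc2ccccc2C)c1` gives 102000 nM in this assay, the highest number of the three measured compounds. The difference between the core of compound 3 and the core of compound 1 is not broken down here; the two differ in more than one place.

Compound 4 `CCNC(=O)Nc1cccc(S(=O)(=O)Nc2ccccc2CC)c1` is not yet measured in this assay. It differs from compound 3 by methyl in place of hydrogen on a saturated chain carbon bound to an aromatic carbon. This is the same kind of change as that from compound 1 to compound 2, but not the same: in compound 4 the entering methyl sits on a saturated chain carbon bound to an aromatic carbon, whereas in compound 2 it sits on a saturated chain carbon two bonds along the chain from an aromatic carbon. Among the compounds with values here, with one prior example only, and that on a different core, the size of the step for compound 4 is expected to be smaller than a 5.0-fold lower number from compound 1 to compound 2 (0.70 log units; beyond the scatter), though in the same direction; the step from compound 3 to compound 4 is estimated as a 2.9-fold lower number from compound 3 to compound 4 (0.46 log units; beyond the scatter), resting on the one measured pair. Compound 4 is therefore expected to give about 35000 nM in this assay, with a range from 12000 nM to 100000 nM.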

Compound 4, half-maximal inhibitory concentration: 15000 nM
For compound 4 the middle estimate is 2.3-fold (0.37 log units) above the measured one; the range from low to high includes it.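

In this assay the added methyl gives a 6.8-fold lower number from compound 3 to compound 4 (0.83 log units; beyond the scatter), the same direction as the step on the core of compound 1, where the change is a 5.0-fold lower number from compound 1 to compound 2 (0.70 log units; beyond the scatter). Set side by side, the two steps do not differ in size, so in this small set the change carries from one core to the other with its size intact: the same change on two cores in this assay, a 5.0-fold lower number (0.70 log units; beyond the scatter) from compound 1 to compound 2 and a 6.8-fold lower number (0.83 log units; beyond the scatter) from compound 3 to compound 4, 1.4-fold (0.13 log units) apart, within the scatter of two such steps

This rests on two pairs only, and the entering methyl does not sit at the same place in them: on a saturated chain carbon bound to an aromatic carbon in compound 4, and on a saturated chain carbon two bonds along the chain from an aromatic carbon in compound 2, so the agreement gives no rule for other chain lengths or other cores, and it offers no explanation of either step.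

The compounds shown leave open whether a propyl chain in place of the ethyl of compound 4 would lower the number further, and whether a butyl chain would extend the series on either core. Also open, going by these compounds, is how a chain ending in an amine or a carboxylic acid would read at this place.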